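This account rests on a few compounds, and the source may have more. Where it says the series, first, only, none or still open, it means among the compounds named here.

Measured in a functional assay on the whole organism for inhibition, with Rattus norvegicus as the target, read by cytopathic effect and paw edema, at a dose of 100 mg/kg by the oral route; on this read-out higher numbers stand for more inhibition at the one dose given (going by the name of the read-out) and lower numbers for less inhibition:
compound 1 `O=C(Nc1ccccn1)c1c(O)c2cccnc2n(-c2ccccc2)c1=O` gives 14.6%
compound 2 `CN(C)CCNC(=O)c1c(O)c2cccnc2n(-c2ccccc2)c1=O` gives 18.4%
compound 3 `Cc1ccc(NC(=O)c2c(O)c3cccnc3n(-c3ccccc3)c2=O)cc1` gives 2.2%

Compound 1 stands second highest of the three numbers. Its gap to compound 2, a number 3.8 percentage points higher from compound 1 to compound 2 (within the scatter), is within the scatter, while the change to compound 3, a number 12.4 percentage points lower from compound 1 to compound 3 (beyond the scatter), lies beyond it. Compound 4 `COc1ccc(NC(=O)c2c(O)c3cccnc3n(-c3ccccc3)c2=O)cc1` differs from compound 1 by 4-methoxyphenyl in place of pyridin-2-yl on an amide-type nitrogen. The step that bears on this is the exchange of pyridin-2-yl for an aromatic ring of carbon only, a number 12.4 percentage points lower from compound 1 to compound 3 (beyond the scatter); the 4-methoxyphenyl entering here is likewise a six-membered aromatic ring of carbon only. For compound 4 a modest downward step of similar size is therefore expected in this assay, a number 9.6 percentage points lower from compound 1 to compound 4 (within the scatter). Compound 4 is thus estimated at about 5%, between 0% and 15%.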

Compound 4, a percentage reported as inhibition, in the whole organism at one dose (the size of the read-out at that dose, not a potency): -1.9%
Beside the measured number, compound 4's estimate is 6.9 percentage points above it; measured number below the stated range.
By their numbers in this assay, from the lowest: compounds 4 and 3 (each within the scatter of the next); then compounds 1 and 2 (each within the scatter of the next).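

On the amide-type nitrogen, 4-methoxyphenyl reads lower than pyridin-2-yl (a number 16.5 percentage points lower from compound 1 to compound 4 (beyond the scatter)) and lower than 2-(dimethylamino)ethyl (a number 20.3 percentage points lower from compound 2 to compound 4 (beyond the scatter)), so the low reading of compound 3 is now matched by a second carbon-only aromatic ring. Methoxy in place of methyl on an aromatic carbon gives no change that can be read (a number 4.1 percentage points lower from compound 3 to compound 4 (within the scatter)). Nothing at hand accounts for these steps.

Open, on these data alone, is what a carboxylic acid or a morpholine ring would give on the amide-type nitrogen. Also open, as far as these compounds go, is how a longer aminoalkyl chain would compare with the 2-(dimethylamino)ethyl of compound 2.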